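The compounds below may be only part of what the source reports. "The series", "measured", "known", "first", "only" and "open" are said of these compounds alone.

Compound 3 `COc1ccc(CNC(=O)/C(C#N)=C/c2ccc(Br)o2)cc1` gives 14000 nM in a functional assay on SMA cells (Homo sapiens) for inhibition, read by MTT assay, with a stated time of 72 h; a higher number here means a weaker inhibitor of growth, a lower number a stronger inhibitor of growth. Compound 2 `COc1ccc(CNC(=O)/C(C#N)=C/c2ccc(Cl)o2)cc1` gives 14000 nM, and the step of no change at the digits printed from compound 2 to compound 3 (within the scatter), so these two hold the lowest number of the three together. Compound 1 `COc1ccc(CNC(=O)/C(C#N)=C/c2ccco2)cc1` gives 33000 nM; the steps of a 2.4-fold lower number from compound 1 to compound 2 (0.37 log units; beyond the scatter) and a 2.4-fold lower number from compound 1 to compound 3 (0.37 log units; beyond the scatter) show what adding a halogen did. Compound 4 `COc1ccc(CNC(=O)/C(C#N)=C/c2ccoc2)cc1` differs from compound 3 by furan-3-yl in place of 5-bromofuran-2-yl on a double-bonded chain carbon bound to a double-bonded chain carbon. Going by the values given here, two changes are combined here: the bromine leaves, which undoes the step recorded as a 2.4-fold lower number from compound 1 to compound 3 (0.37 log units; beyond the scatter), and the ring becomes furan-3-yl rather than 5-bromofuran-2-yl, for which no measured pair exists. The expected step is a 2.4-fold higher number from compound 3 to compound 4 (0.37 log units; beyond the scatter). Compound 4 is therefore estimated at 33000 nM, with a range from 12000 nM to 90000 nM.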

Compound 4, concentration for 50% growth inhibition: 7000 nM
Compound 4: the middle estimate sits 4.7-fold (0.67 log units) above what was measured, outside the stated range (below it).
By their numbers in this assay, from the lowest: compounds 4, 2 and 3 (each within the scatter of the next); then compound 1.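

In this assay furan-3-yl, which carries no halogen, stands level with the halogenated furan-2-yl rings, with a 2.0-fold lower number from compound 3 to compound 4 (0.30 log units; within the scatter) and a 2.0-fold lower number from compound 2 to compound 4 (0.30 log units; within the scatter) at this position. Against the unsubstituted furan-2-yl ring there is a 4.7-fold lower number from compound 1 to compound 4 (0.67 log units; beyond the scatter) and so, among these compounds, a halogen is not needed to reach the lowest group of numbers. Nothing measured here explains this result. Still open, on these data alone, is what a chlorine or bromine on furan-3-yl would do, and how a phenyl ring or a ring carrying an amine would compare on this chain carbon.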